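The compounds below may be only part of what the source reports. "The series", "measured", "known", "first", "only" and "open" are said of these compounds alone.

Of the compounds shown here, three built on one shared core have been measured in an assay on isolated protein for displacement of a labelled ligand from metabotropic glutamate receptor 5 (Homo sapiens), with a stated time of 60 min, tested at 1 uM; a higher number here means more inhibition at the concentration tested (going by the name of the read-out), a lower number less inhibition. Compound 1 `CC1CCN(c2c(S(=O)(=O)c3cc(Cl)cc(Cl)c3)cnc3ccc(F)cc23)CC1` gives 69%. Compound 2 `COc1ccc(S(=O)(=O)c2cnc3ccc(F)cc3c2N2CCC(C)CC2)cc1` gives 85%, and compound 3 `Cc1cc(C)cc(S(=O)(=O)c2cnc3ccc(F)cc3c2N2CCC(C)CC2)c1` gives 83%, the second highest of the three numbers. The steps of a number 16 percentage points higher from compound 1 to compound 2 (beyond the scatter) and a number 14 percentage points higher from compound 1 to compound 3 (beyond the scatter) both lie beyond the scatter, whereas the step of a number 2 percentage points lower from compound 2 to compound 3 (within the scatter) lies within it. Compound 4 `CC1CCN(c2c(S(=O)(=O)c3cccc(Cl)c3)cnc3ccc(F)cc23)CC1` is not yet measured; it differs from compound 3 by 3-chlorophenyl in place of 3,5-dimethylphenyl on a sulfonyl sulfur. A downward step is expected because compound 1 with 3,5-dichlorophenyl on the sulfonyl sulfur gives only 69%. With a single chlorine entering, the expected step is a number 7 percentage points lower from compound 3 to compound 4 (within the scatter). Compound 4 is estimated at 76%, between 62% and 88%.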

Compound 4, a percentage reported as inhibition, at one concentration (the size of the read-out at that concentration, not a potency): 92%
Compound 4: the middle estimate sits 16 percentage points below what was measured, outside the stated range (above it).
By their numbers in this assay, from the lowest: compound 1; then compounds 3, 2 and 4 (each within the scatter of the next).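

On the sulfonyl sulfur, one chlorine on the phenyl ring keeps the number level with the other aryl groups in this assay: a number 9 percentage points higher from compound 3 to compound 4 (within the scatter) and a number 7 percentage points higher from compound 2 to compound 4 (within the scatter) both stay small. The low number therefore goes with 3,5-dichlorophenyl, not with chlorine as such, as a number 23 percentage points higher from compound 1 to compound 4 (beyond the scatter) shows for hydrogen in place of chloro on an aromatic carbon. Nothing available explains this difference.

From the compounds shown here alone, whether a phenyl carrying an amine or a carboxylic acid would hold this level on the sulfonyl sulfur remains open. So does whether a full potency measurement would separate compound 2, compound 3 and compound 4.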